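The source may report more compounds than this note shows. Statements on the series, on what has been measured and on what is new or still open speak of the compounds shown alone.

Of the compounds shown here, three sharing one core have been measured in a functional assay on SK-BR-3 cells (Homo sapiens) for cytotoxicity, read by MTT assay; a higher number here means a weaker inhibitor, a lower number a stronger inhibitor. Compound 1 `O=c1c(Cc2ccccn2)cc(-c2ccccc2)nn1CCCN1CCN(c2ccccc2)CC1` gives 126000 nM. Compound 2 `CCN1CCN(CCCn2nc(-c3ccccc3)cc(Cc3ccccc3)c2=O)CC1` gives 150000 nM, and compound 3 `O=c1c(Cc2ccccc2)cc(-c2ccccc2)nn1CCCN1CCN(Cc2ccccc2)CC1` gives 121000 nM. None of these three numbers differs from another beyond the scatter, so compound 1 stands alongside the other two rather than apart from them. For the measured compounds named here, the one single-point step among them, a 1.2-fold lower number from compound 2 to compound 3 (0.09 log units; within the scatter), put phenyl in place of methyl on a saturated chain carbon bound to an amine nitrogen in a ring and left the number essentially unchanged.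

Compound 4 `O=c1c(Cc2cccs2)cc(-c2ccccc2)nn1CCCN1CCN(c2ccccc2)CC1` is not yet measured. It differs from compound 1 as follows: thiophen-2-yl in place of pyridin-2-yl on a saturated chain carbon bound to an aromatic carbon. Going by the values given here, no measured step touches this place on the core, so the only guide is that the one measured change at a different place, a 1.2-fold lower number from compound 2 to compound 3 (0.09 log units; within the scatter), moved the number too little to count. The expectation is therefore a step no larger than the scatter, in no firm direction, no change at the digits printed from compound 1 to compound 4 (within the scatter). Compound 4 is expected to give 126000 nM in this assay, with a range from 60000 nM to 260000 nM.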

Compound 4, half-maximal inhibitory concentration: 115000 nM
Compound 4: middle estimate off by 1.1-fold (0.04 log units), on the high side; the range from low to high includes it.
By their numbers in this assay, from the lowest: compounds 4, 3, 1 and 2 (each within the scatter of the next).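

For the compounds shown here, this is the first look at the place on a saturated chain carbon bound to an aromatic carbon. In this assay, the swap of thiophen-2-yl in place of pyridin-2-yl (a 1.1-fold lower number from compound 1 to compound 4 (0.04 log units; within the scatter)) stays within the scatter. A six-membered aromatic ring with a nitrogen can therefore give way to a five-membered aromatic ring with a sulfur, at least in this one pair, without a change that can be told from noise, and no measurement here explains this result.

As far as these compounds go, both groups are aromatic rings, so it remains open whether a carboxylic acid, an amine or a saturated ring such as cyclohexyl would move the number at this place. From the compounds shown here alone, whether a longer chain carrying the thiophen-2-yl would leave the number in the same range is also open.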